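The source may hold more compounds than are shown below. What is called first, only, known or untested is meant among the compounds shown, and "the series" means these compounds.

Of the compounds shown here, two built on a shared core have so far been tested in a functional assay on cells (Peritoneal macrophage, Mus musculus) for cytotoxicity, with a stated time of 24 h; a lower number here means that less compound is tolerated, a higher number that more compound is tolerated. Compound 1 `COc1ccc(S(=O)(=O)N(CC(N)=O)c2ccc(N(CC(N)=O)S(=O)(=O)c3ccc(NC(=O)CN4CCCCC4)cc3)c3ccccc23)cc1` gives > 100000 nM, which is a limit of the assay and not a number. Compound 2 `COc1ccc(S(=O)(=O)N(CC(N)=O)c2ccc(N(CC(N)=O)S(=O)(=O)c3ccc(NC(=O)CN4CCN(C(C)C)CC4)cc3)c3ccccc23)cc1` gives > 100000 nM, again only a limit. So compound 2 has no exact value, and the same is true of the only other compound measured: the limit of > 100000 nM in this assay, at which 2 of the 2 values shown sit.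

Among the compounds with values here, the single measured change is a step that the two limits leave unreadable from compound 1 to compound 2, with 4-isopropylpiperazin-1-yl in place of piperidin-1-yl on a saturated chain carbon bound to a carbonyl carbon. It gives no size to build on.

Compound 3 `COc1ccc(S(=O)(=O)N(CC(N)=O)c2ccc(N(CC(N)=O)S(=O)(=O)c3ccc(NC(=O)CCN4CCN(C(C)C)CC4)cc3)c3ccccc23)cc1` carries (4-isopropylpiperazin-1-yl)methyl in place of 4-isopropylpiperazin-1-yl at that same place on a saturated chain carbon bound to a carbonyl carbon: (4-isopropylpiperazin-1-yl)methyl in place of 4-isopropylpiperazin-1-yl on a saturated chain carbon bound to a carbonyl carbon. This small extension of the chain is a modest change, and neither measured compound gives any direction for it in this assay. No change beyond the scatter is therefore expected, and the expected step is a step that the limit leaves unreadable from compound 2 to compound 3. A further limit is the most likely report. For compound 3 the estimated value is 120000 nM, with an expected range from 50000 nM to 300000 nM.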

Compound 3, half-maximal cytotoxic concentration: > 100000 nM
Compound 3: a limit, no number (the forecaster's own chance of this, stated with the estimate: 80%); the middle value lies beyond the limit too.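

In this assay compound 3 gives > 100000 nM, again a limit of the assay and not a number. No step among compound 1, compound 2 and compound 3 can be read, since all three stop at the same point: the limit of > 100000 nM in this assay, at which 3 of the 3 values shown sit.

The compounds shown leave open at what concentration, if any, these three become cytotoxic to the cells, and whether the changes on the chain alter that concentration.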